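This account rests on a few compounds, and the source may have more. Where it says the series, first, only, none or still open, it means among the compounds named here.

Compound 1 `CCCc1nn(C)c2c1C(c1ccccc1Cl)=NCC(=O)N2` and compound 2 `CCCCc1nn(C)c2c1C(c1ccccc1Cl)=NCC(=O)N2` share one core, and compound 2 carries methyl in place of hydrogen on a saturated chain carbon, three bonds along the chain from an aromatic carbon. In a functional assay on the whole organism (strain Holtzman) with Rattus norvegicus as the target (a lower number here means that less compound is needed, a higher number that more compound is needed for the effect), compound 1 gives only a limit of the assay, > 40 mg/kg. Compound 2 likewise gives only a limit in this assay, > 40 mg/kg. The step between them, a step that the two limits leave unreadable from compound 1 to compound 2, therefore cannot be read in size. Compound 3 `CCn1nc(C)c2c1NC(=O)CN=C2c1ccccc1Cl` rests on another core; the difference between the core of compound 3 and the core of compound 1 is not broken down here. In this assay, among the measured compounds shown here, compound 3 gives 5 mg/kg, the only number among the three measured values, the other two sitting at the limit of > 40 mg/kg in this assay, at which 2 of the 3 values shown sit.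

Compound 4 `CCCn1nc(C)c2c1NC(=O)CN=C2c1ccccc1Cl` differs from compound 3 by methyl in place of hydrogen on a saturated chain carbon, two bonds along the chain from an aromatic nitrogen. For the measured compounds named here, this is the same kind of change as the one from compound 1 to compound 2, but not the same: there the methyl enters three bonds along the chain from an aromatic carbon, here two bonds along the chain from an aromatic nitrogen. The earlier step offers no measure to lean on, since both of its ends are limits. Going by the values given here, the estimate for the step of a 2.0-fold higher number from compound 3 to compound 4 (0.30 log units; within the scatter) is a small move toward a higher dose, and it rests only on compound 3 being the sole compound with a number, 5 mg/kg. Compound 4 is expected to give about 10 mg/kg in this assay, between 3 mg/kg and 40 mg/kg.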

Compound 4, minimum effective dose: 40 mg/kg
Beside the measured number, compound 4's estimate is 4.0-fold (0.60 log units) below it, and the stated range covers the measured number.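

In this assay, methyl in place of hydrogen on a saturated chain carbon, two bonds along the chain from an aromatic nitrogen, gives an 8.0-fold higher number from compound 3 to compound 4 (0.90 log units; beyond the scatter), so on the core of compound 3 this lengthening from ethyl to propyl comes with a need for more compound. The related change on the core of compound 1 offers no size to compare, and compound 1 and compound 2 each stop at a limit rather than a number, so their step cannot be read: the limit of > 40 mg/kg in this assay, at which 2 of the 4 values shown sit. The result therefore gives one readable instance on one core and does not show that the change carries over, as the two changes also differ in place, the earlier one lying three bonds along the chain from an aromatic carbon.

The compounds shown leave open whether a longer chain, such as butyl, in the place of the propyl of compound 4 would continue this direction or whether the step seen here is specific to going from ethyl to propyl. They also leave open how this chain would read in the same assay if it ended in an amine or a carboxylic acid.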